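Shifting a Hydroxyl Group Between Compound 3 and Compound 4

A few compounds are considered here, and "the series" means these few. Any claim that something is new, unique, unknown or untested is made for them only; others in the source may bear on it.

Measured compounds:
Compound 1 `Oc1ccc(-c2cc(-c3ccc(F)cc3)cc(-c3cccc(O)c3)n2)cc1` gives 8080 nM in a functional assay on HeLa cells (Homo sapiens) for inhibition; on this read-out lower numbers stand for stronger inhibition and higher numbers for weaker inhibition.
Compound 2 `Oc1cccc(-c2cc(-c3cccc(C(F)(F)F)c3)cc(-c3ccccc3O)n2)c1` gives 19500 nM in this assay.
Compound 3 `Oc1cccc(-c2cc(-c3cccc(C(F)(F)F)c3)cc(-c3cccc(O)c3)n2)c1` gives 12700 nM in this assay.

All three numbers lie within the usual scatter of one another, so compound 3 cannot be set apart from compound 2 or compound 1 in this assay; its number is simply one of three that cannot be told apart. Within the data shown here, the one step that can be followed is a 1.5-fold lower number from compound 2 to compound 3 (0.19 log units; within the scatter), a shift of the hydroxyl group that left the number unchanged beyond the scatter.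

Compound 4 `Oc1ccc(-c2cc(-c3cccc(C(F)(F)F)c3)cc(-c3cccc(O)c3)n2)cc1` has not yet been measured. It differs from compound 3 in one place: 4-hydroxyphenyl in place of 3-hydroxyphenyl on an aromatic carbon. Among the measured compounds shown here, no measured pair traces this particular move of the hydroxyl group, since compound 1 and compound 3 differ in two places and only show that their two numbers are within the scatter. The nearest evidence, the hydroxyl shift from compound 2 to compound 3, gave no step beyond the scatter, so the expectation is that compound 4 will likewise show no step beyond the scatter in this assay, which is what a 1.2-fold lower number from compound 3 to compound 4 (0.06 log units; within the scatter) means. Compound 4 is therefore estimated at 11000 nM, expected to fall between 4000 nM and 30000 nM.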

Compound 4, half-maximal inhibitory concentration: 16200 nM
For compound 4 the middle estimate is 1.5-fold (0.17 log units) below the measured one, within the range that was stated.
By their numbers in this assay, from the lowest: compounds 1, 3, 4 and 2 (each within the scatter of the next, the first and the last beyond it).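

With the 3-(trifluoromethyl)phenyl group held constant, the position next to the ring nitrogen can now be compared across 2-hydroxyphenyl, 3-hydroxyphenyl and 4-hydroxyphenyl. In this assay, the change to 4-hydroxyphenyl gives a 1.3-fold higher number from compound 3 to compound 4 (0.11 log units; within the scatter) and a 1.2-fold lower number from compound 2 to compound 4 (0.08 log units; within the scatter), so the three placements of the hydroxyl group cannot be told apart at this position. Compound 4 also adds a single-place comparison of a different substituent, with 3-(trifluoromethyl)phenyl in place of 4-fluorophenyl giving a 2.0-fold higher number from compound 1 to compound 4 (0.30 log units; within the scatter), so neither kind of change shown here moves the number beyond the scatter.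

No available evidence accounts for how closely these numbers agree. From the compounds shown here alone, it remains open whether this position would respond to a change other than moving the hydroxyl group, such as a methoxy group in its place, an aminophenyl group or a phenyl group carrying a carboxylic acid.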